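Notes on a purine nucleoside series against a nucleoside transporter

The compounds below may be only part of what the source reports. "The series", "measured", "known", "first", "only" and "open" are said of these compounds alone.

The series is scored in an assay on isolated protein for binding affinity to Equilibrative nucleoside transporter 1 (Homo sapiens); a higher number here means a weaker inhibitor, a lower number a stronger inhibitor. Compound 1 `OC[C@H]1O[C@@H](n2cnc3c(OCc4ccccc4)ncnc32)[C@H](O)[C@@H]1O` is the reference of this set; in this assay compound 1 gives 2090 nM. Within the data shown here, compound 2 `CCCCn1cnc2c(SC(C)C)nc(N)nc21` is the only other measured member, and in this assay compound 2 gives 120000 nM, a considerably higher number than compound 1, a gap that lies beyond the usual scatter. Among the measured compounds shown here, compound 1 thus holds the lowest number of the two measured, though compound 2 is not a single-point neighbour of it, so no measured step is available to calibrate the change below.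

Compound 3 `OC[C@H]1O[C@@H](n2cnc3c(CSc4cccc(Br)c4)ncnc32)[C@H](O)[C@@H]1O` is the next candidate for this assay. Relative to compound 1 the change is ((3-bromophenyl)sulfanyl)methyl in place of benzyloxy on an aromatic carbon. With no measured step of this kind in hand, the expectation is a step from compound 1 to compound 3 of a 1.4-fold lower number from compound 1 to compound 3 (0.14 log units; within the scatter), that is, no change beyond the scatter in either direction. Compound 3 is therefore estimated at 1500 nM, with a plausible range from 300 nM to 8000 nM.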

Compound 3, half-maximal inhibitory concentration: 363 nM
For compound 3 the middle estimate is 4.1-fold (0.62 log units) above the measured one; low and high end bracket the measured number.
By their numbers in this assay, from the lowest: compound 3; then compound 1; then compound 2.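

In this assay, among these compounds, replacing benzyloxy with ((3-bromophenyl)sulfanyl)methyl on the same aromatic carbon gives a 5.8-fold lower number from compound 1 to compound 3 (0.76 log units; beyond the scatter), the first calibrated step. This position therefore accepts a group that retains a six-membered aromatic ring of carbon only while exchanging oxygen for sulfur and adding bromine, and the number moves modestly lower rather than being lost. No measurement shown bears on the reason for this step.

The sulfur-containing linker and the bromine enter together, so their separate contributions remain unresolved; (phenylsulfanyl)methyl without bromine would be the direct comparison. Also open, as far as these compounds go, is whether an amine or a longer alkyl chain on this aromatic carbon would retain the lower number seen with compound 3.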